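The source may report more compounds than this note shows. Statements on the series, on what has been measured and on what is new or still open speak of the compounds shown alone.

Compound 1 `COC(=O)/C(=C/c1ccccc1)CN1C(=O)[C@@H](OC)[C@H]1c1ccccc1C(F)(F)F` gives 17600 nM 
Compound 2 `COC(=O)/C(=C/c1ccccc1)CN1C(=O)[C@@H](OC)[C@H]1c1cccc(F)c1` gives 34400 nM 

Among the measured compounds shown here, both numbers come from a functional assay on MDA-MB-231 cells (Homo sapiens) for antiproliferative activity, read by MTT assay, with a stated time of 48 h (a higher number here means a weaker inhibitor, a lower number a stronger inhibitor), and compound 2 stands within the scatter of compound 1, its only measured neighbour. Compound 3 `COC(=O)/C(=C/c1ccccc1)CN1C(=O)[C@@H](OC)[C@H]1c1cccc(C(F)(F)F)c1` differs from compound 2 by trifluoromethyl in place of fluoro on an aromatic carbon in the form of trifluoromethyl in place of fluoro on an aromatic carbon, meta to a large group. For the measured compounds named here, the one measured step bearing on this is a 2.0-fold higher number from compound 1 to compound 2 (0.29 log units; within the scatter) and it exchanges 2-(trifluoromethyl)phenyl for 3-fluorophenyl. No step beyond the scatter is therefore expected in this assay for this change. The expected step is a 1.4-fold lower number from compound 2 to compound 3 (0.16 log units; within the scatter) in size. For compound 3 the estimated value is 24000 nM with an expected range from 11000 nM to 50000 nM here.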

Compound 3, half-maximal inhibitory concentration: 18200 nM
Compound 3: the middle estimate sits 1.3-fold (0.12 log units) above what was measured, within the range that was stated.
By their numbers in this assay, from the lowest: compounds 1, 3 and 2 (each within the scatter of the next).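

In this assay, 3-(trifluoromethyl)phenyl in place of 3-fluorophenyl gives a 1.9-fold lower number from compound 2 to compound 3 (0.28 log units; within the scatter), so the larger trifluoromethyl group at this position leaves the read-out within the scatter. With trifluoromethyl kept and its place on the phenyl group changed, the result is a 1.0-fold higher number from compound 1 to compound 3 (0.01 log units; within the scatter), so 2-(trifluoromethyl)phenyl and 3-(trifluoromethyl)phenyl cannot be told apart here. No evidence bearing on these results is available. The compounds shown leave open whether an amine or a carboxylic acid on this phenyl group would give a step beyond the scatter.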